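This account rests on a few compounds, and the source may have more. Where it says the series, first, only, none or still open, it means among the compounds named here.

Measured so far:
- compound 1 `O=C1Nc2ccccc2/C1=N/NC(=S)NCc1ccccc1`: 7630 nM
- compound 2 `COc1cc(NC(=S)N/N=C2\C(=O)Nc3ccccc32)cc(OC)c1OC`: 3490 nM

In a functional assay on KB-V1 cells (Homo sapiens) for cytotoxicity, read by MTT assay, with a stated time of 72 h (on this read-out lower numbers stand for stronger inhibition and higher numbers for weaker inhibition), compound 1 gives 7630 nM, the higher of the two numbers. Compound 2 gives 3490 nM, a lower number, and the gap between the two lies beyond the usual scatter. Compound 1 therefore stands at the weak end of this small set.

The next compound to be read is compound 3 `O=C1Nc2ccccc2/C1=N/NC(=S)Nc1ccc(Cl)cc1`. It carries 4-chlorophenyl in place of benzyl on an amide-type nitrogen. Among the compounds with values here, no measured step at this place exists, so the expectation rests on thin ground. Within the data shown here, the only lower reference is compound 2 at 3490 nM, and a result near that number is the working assumption. A modest move towards stronger inhibition in this assay is expected, and the estimated step is a 2.2-fold lower number from compound 1 to compound 3 (0.34 log units; beyond the scatter). A result with no change beyond the scatter would not be surprising. For compound 3 the expected value is 3500 nM, with an estimated range from 1300 nM to 9500 nM.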

Compound 3, half-maximal inhibitory concentration: 4990 nM
Compound 3: the middle estimate sits 1.4-fold (0.15 log units) below what was measured; low and high end bracket the measured number.
By their numbers in this assay, from the lowest: compounds 2, 3 and 1 (each within the scatter of the next, the first and the last beyond it).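

In this assay, 4-chlorophenyl in place of benzyl on an amide-type nitrogen, whose other neighbour is the thiocarbonyl carbon, gives a 1.5-fold lower number from compound 1 to compound 3 (0.18 log units; within the scatter). Within the data shown here, this is the first step read at this position, and it shows that the exchange leaves the read-out within the scatter, even though the entering group carries chlorine and the leaving group does not, while each brings one six-membered aromatic ring of carbon only. No measurement on hand offers an explanation for this result.

From the compounds shown here alone, a single step cannot separate the contribution of the chlorine from that of replacing benzyl with an aryl group directly on the nitrogen, so plain phenyl, or 4-chlorobenzyl, would be the informative partner for compound 1 and compound 3, and it remains open whether this tolerance extends to a longer chain such as 2-phenylethyl or to a ring bearing an amine or a carboxylic acid. Among these compounds, compound 2 has no one-place step to either compound 1 or compound 3, so the contribution of its methoxy groups also remains unresolved.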